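Compound 2 at the limit, compound 3 to come

The source may report more compounds than this note shows. Statements on the series, on what has been measured and on what is new or still open speak of the compounds shown alone.

Values so far in a functional assay on A2780 cells (Homo sapiens) for antiproliferative activity, read by sulforhodamine B assay, with a stated time of 48 h (on this read-out lower numbers stand for stronger inhibition of growth and higher numbers for weaker inhibition of growth), for growth inhibition
Compound 1 (`C=CCOC[C@H]1OCCC[C@H]1O[Si](C)(C)C(C)(C)C`): 15000 nM
Compound 2 (`CC(C)(C)[Si](C)(C)O[C@@H]1CCCO[C@@H]1CO/C=C/CO`): > 100000 nM (a limit)

Compound 2 has no exact place on the scale and stands at the limit of > 100000 nM in this assay, at which 1 of the 2 values shown sits, as a limit, not a number. Compound 3 (`COC(=O)CCOC[C@H]1OCCC[C@H]1O[Si](C)(C)C(C)(C)C`) keeps the shared core but carries 2-(methoxycarbonyl)ethyl in place of 3-hydroxyprop-1-en-1-yl on an oxygen on a saturated carbon, a change counted as 2-(methoxycarbonyl)ethyl in place of 3-hydroxyprop-1-en-1-yl on an oxygen on a saturated carbon with nothing else altered. Among the compounds with values here, one measured step bears on this place: an at least 6.6-fold higher number from compound 1 to compound 2 (0.82 log units; beyond the scatter) when 3-hydroxyprop-1-en-1-yl replaced allyl. Compound 3 loses that group again, so a partial return towards compound 1 at 15000 nM is expected, on thin support. Expected in this assay is an at least 2.8-fold lower number from compound 2 to compound 3 (0.45 log units; beyond the scatter) towards stronger inhibition. The estimated value for compound 3 is 35000 nM, expected to lie from 10000 nM to 100000 nM on this read-out.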

Compound 3, concentration for 50% growth inhibition: > 100000 nM
Compound 3: no number, only a limit; the forecaster's own chance of this, stated with the estimate: 30%; at least 2.8-fold (0.45 log units) between middle value and limit.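

In this assay, compound 3 gives > 100000 nM, which is a limit and not a number. With 2-(methoxycarbonyl)ethyl as the second group tried in place of allyl, the change from the allyl compound gives an at least 6.6-fold higher number from compound 1 to compound 3 (0.82 log units; beyond the scatter), so both replacements shown for allyl on this oxygen lead to weaker growth inhibition, and compound 1 remains the only compound here with an exact value. The step from compound 2 to compound 3 cannot be read, so 3-hydroxyprop-1-en-1-yl and 2-(methoxycarbonyl)ethyl cannot be ranked against each other, and the series now rests largely on: the limit of > 100000 nM in this assay, at which 2 of the 3 values shown sit.

From the compounds shown here alone, whether a plain propyl chain would keep the activity of compound 1 stays open. So does whether a chain ending in an amine or a carboxylic acid would keep or improve it.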